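Swapping the aryl group on the hydrazone carbon

The source may report more compounds than this note shows. Statements on the series, on what has been measured and on what is new or still open speak of the compounds shown alone.

Compounds measured so far:
- compound 1 `CN(C)CCn1cnnc1-c1cc(Oc2ccc(NC(=O)N/N=C/c3c(Cl)cccc3Cl)cc2F)ccn1`: 350 nM
- compound 2 `CN(C)CCn1cnnc1-c1cc(Oc2ccc(NC(=O)N/N=C/c3ccc(F)cc3F)cc2F)ccn1`: 1930 nM

Both compounds were tested in a functional assay on NCI-H460 cells (Homo sapiens) for cytotoxicity, read by MTT assay, with a stated time of 72 h; on this read-out lower numbers stand for stronger inhibition and higher numbers for weaker inhibition. Going by the values given here, of the two numbers known, compound 2 gives the higher one, 1930 nM, while compound 1 gives 350 nM. Among the compounds with values here, the only measured step, a 5.5-fold higher number from compound 1 to compound 2 (0.74 log units; beyond the scatter), shows that changing the aryl ring on the carbon with a double bond to nitrogen moves the number well beyond the scatter.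

Compound 3 `CN(C)CCn1cnnc1-c1cc(Oc2ccc(NC(=O)N/N=C/c3ccc(Cl)cc3)cc2F)ccn1` is not yet measured. It differs from compound 2 by 4-chlorophenyl in place of 2,4-difluorophenyl on a carbon with a double bond to nitrogen. This is a change at the same position as the measured step, and in that step the ring carrying chlorine gave the lower number. Compound 3 again carries a chlorine on this ring, though with a different pattern, so a direct transfer is uncertain. On this basis a modest move toward lower numbers is expected, a 2.1-fold lower number from compound 2 to compound 3 (0.33 log units; beyond the scatter), rather than a step of the full size seen before. Compound 3 is therefore estimated at 900 nM in this assay, with a range from 300 nM to 2700 nM.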

Compound 3, half-maximal inhibitory concentration: 320 nM
Compound 3: the middle estimate sits 2.8-fold (0.45 log units) above what was measured, and the stated range covers the measured number.
By their numbers in this assay, from the lowest: compounds 3 and 1 (each within the scatter of the next); then compound 2.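

The new value shows that this position does not simply reward any change of ring: in this assay, replacing 2,4-difluorophenyl with 4-chlorophenyl gives a 6.0-fold lower number from compound 2 to compound 3 (0.78 log units; beyond the scatter), a step about as large as the first one measured here. The second comparison adds something the first could not show, since 4-chlorophenyl in place of 2,6-dichlorophenyl gives a 1.1-fold lower number from compound 1 to compound 3 (0.04 log units; within the scatter), so among these compounds the number of chlorine atoms and their placement on the ring make no difference that can be told from scatter, and both chlorine-bearing compounds stand apart from compound 2, with none of the three going against this. No measurement is available that explains why the rings differ in this way.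

On these data alone, the step from compound 2 to compound 3 removes two fluorine atoms and adds one chlorine at once, so it remains open whether gaining the chlorine or losing the fluorines matters more, a question that 4-fluorophenyl or plain phenyl on this carbon could help answer. As far as these compounds go, it also remains open how this position would respond to a ring carrying a methoxy group, an amine or a carboxylic acid.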